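This account rests on a few compounds, and the source may have more. Where it says the series, first, only, none or still open, it means among the compounds named here.

Of the compounds shown here, three have been tested in a functional assay on the whole organism (strain CD1) for inhibition, with Mus musculus as the target, with stated times of 15 min and 20 min, at a dose of 10 mg/kg by the subcutaneous route; a higher number here means more inhibition at the dose given (going by the name of the read-out), a lower number less inhibition. Compound 1 `N#C/C(=C\c1ccccc1)C(=O)OC1CCCCC1` gives 7.1%. Compound 2 `CCOC(=O)/C(C#N)=C/c1ccoc1` gives 55.9%, and compound 3 `CC(C)(C)OC(=O)/C(C#N)=C/c1ccoc1` gives 81.8%, the highest of the three numbers, standing beyond the scatter above both. For the measured compounds named here, the one single-point step measured so far, a number 25.9 percentage points higher from compound 2 to compound 3 (beyond the scatter), shows that a larger ester group can raise inhibition. Compound 4 `N#C/C(=C\c1ccoc1)C(=O)OC1CCCCC1` carries cyclohexyl in place of tert-butyl on an oxygen next to a carbonyl group. Going by the values given here, no measured step tests this exact exchange; compound 1 also bears a cyclohexyl, but differs from compound 4 in another place as well, so its low number is only a loose pointer. Compound 4 is therefore expected near 60%, within 20% to 90%, an estimated step of a number 21.8 percentage points lower from compound 3 to compound 4 (beyond the scatter) in this assay.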

Compound 4, a percentage reported as inhibition, in the whole organism at one dose (the size of the read-out at that dose, not a potency): 91.2%
Compound 4: middle estimate off by 31.2 percentage points, on the low side; the whole stated range lies below it.
By their numbers in this assay, from the lowest: compound 1; then compound 2; then compounds 3 and 4 (each within the scatter of the next).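

On an oxygen next to a carbonyl group, cyclohexyl in place of tert-butyl gives a number 9.4 percentage points higher from compound 3 to compound 4 (within the scatter), so these two groups cannot be told apart here, while cyclohexyl in place of ethyl gives a number 35.3 percentage points higher from compound 2 to compound 4 (beyond the scatter). With cyclohexyl held fixed, furan-3-yl in place of phenyl gives a number 84.1 percentage points higher from compound 1 to compound 4 (beyond the scatter), so the low number of compound 1 goes with the phenyl, not the cyclohexyl. Nothing available explains these differences. Still open, from the compounds shown here alone, is how a longer chain or an amine would fare on that oxygen. Going by these compounds, it is also open whether the gain from furan-3-yl over phenyl holds with other ester groups.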